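The source may report more compounds than this note shows. Statements on the series, on what has been measured and on what is new or still open speak of the compounds shown alone.

Compounds measured in an assay on isolated protein for binding affinity to adenosine receptor A1 (Bos taurus); on this read-out lower numbers stand for stronger inhibition and higher numbers for weaker inhibition:

Compound 1 `CNc1nc(-c2ccccc2)nc2c1nnn2Cc1ccccc1F` gives 25000000 nM.
Compound 2 `CCCCCCNc1nc(-c2ccccc2)nc2c1nnn2Cc1ccccc1F` gives 25000000 nM.
Compound 3 `COc1ccc(C(=O)Nc2nc(-c3ccccc3)nc3c2nnn3Cc2ccccc2F)cc1` gives 21900000 nM.

Compound 3 carries the lowest of these three numbers, but its nearest neighbour on this read-out is compound 1, and the step from compound 1 to compound 3 is a 1.1-fold lower number from compound 1 to compound 3 (0.06 log units; within the scatter), so the three values cannot be told apart. Compound 4 `CCNc1nc(-c2ccccc2)nc2c1nnn2Cc1ccccc1F` has not yet been measured in this assay. The change from compound 3 to compound 4 is ethyl in place of (4-methoxyphenyl)carbonyl on a nitrogen on an aromatic ring. For the measured compounds named here, three measured steps bear on it. The step from compound 2 to compound 3 is a 1.1-fold lower number from compound 2 to compound 3 (0.06 log units; within the scatter), the step from compound 1 to compound 3 is a 1.1-fold lower number from compound 1 to compound 3 (0.06 log units; within the scatter), and the step from compound 1 to compound 2 is no change at the digits printed from compound 1 to compound 2 (within the scatter); in each case an alkyl group and the (4-methoxyphenyl)carbonyl group on this nitrogen give numbers within the scatter of one another. Because no change at the digits printed from compound 1 to compound 2 (within the scatter) shows the alkyl compounds agreeing as well, an ethyl group is expected to behave like them, and the expected step from compound 3 to compound 4 is a 1.1-fold higher number from compound 3 to compound 4 (0.06 log units; within the scatter). Compound 4 is therefore estimated at 25000000 nM, with a range from 12000000 nM to 50000000 nM.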

Compound 4, inhibition constant: 11000000 nM
Estimate against measurement, compound 4: 2.3-fold (0.36 log units) above; the whole stated range lies above it.
By their numbers in this assay, from the lowest: compounds 4, 3, 1 and 2 (each within the scatter of the next, the first and the last beyond it).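

In this assay, compound 4 shows that the group on this nitrogen can shift the number beyond the scatter, though only modestly (a 2.3-fold lower number from compound 1 to compound 4 (0.36 log units; beyond the scatter); a 2.3-fold lower number from compound 2 to compound 4 (0.36 log units; beyond the scatter)). The methyl and hexyl chains had agreed with each other, so ethyl stands apart from both and the three chains form no steady trend with length, while the (4-methoxyphenyl)carbonyl group of compound 3 cannot be separated from ethyl (a 2.0-fold lower number from compound 3 to compound 4 (0.30 log units; within the scatter)). No supporting evidence here accounts for this difference.

From the compounds shown here alone, it remains open whether a propyl or butyl chain would side with ethyl or with the methyl and hexyl chains, which would show if the shift is real or confined to ethyl alone. The compounds shown also leave open how a branched isopropyl group or a bare amine at this position would read.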